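A few compounds are considered here, and "the series" means these few. Any claim that something is new, unique, unknown or untested is made for them only; others in the source may bear on it.

In a functional assay on MCF7 cells (Homo sapiens) for inhibition, read by radiometric assay and XTT assay (a higher number here means a weaker inhibitor, a lower number a stronger inhibitor), compound 1 (`CCCCCC[C@@]1(C)SC(=O)C=C1OCCCCCl`) reads 20.8 ug/mL and compound 2 (`C=CCOC1=CC(=O)S[C@]1(C)CCCCCC`) reads 9 ug/mL on the same scale. Compound 3 (`C=CCOC1=CC(=O)S[C@]1(C)CCCCCCCC`) reads 14.5 ug/mL and so lies within the usual scatter of both, although those two differ from each other by more than the scatter. Compound 4 (`CCCCCCCC[C@@]1(C)SC(=O)C=C1OC(=O)OCC`) has not yet been measured. It departs from compound 3 by a single change (ethoxycarbonyl in place of allyl on an oxygen on an unsaturated carbon), which is ethoxycarbonyl in place of allyl on an oxygen on an unsaturated carbon.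

Two measured steps offer some guidance. The closer one alters the group on that same oxygen and gives a modest step (a 2.3-fold lower number from compound 1 to compound 2 (0.36 log units; beyond the scatter)) in the numbers. The other puts ethyl in place of hydrogen on a saturated chain carbon and stays within the scatter (a 1.6-fold higher number from compound 2 to compound 3 (0.21 log units; within the scatter)) in size. Within the data shown here, no measured compound carries ethoxycarbonyl, so the data leave the direction open. No step beyond the scatter is expected in this assay here, though a modest one either way remains possible. The estimated step is small (a 1.0-fold lower number from compound 3 to compound 4 (0.02 log units; within the scatter)) and rests on little evidence. For compound 4 the expected value is 14 ug/mL with an estimated range from 6 ug/mL to 32 ug/mL as the likely span.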

Compound 4, half-maximal inhibitory concentration: 15.1 ug/mL
Beside the measured number, compound 4's estimate is 1.1-fold (0.03 log units) below it; measured number inside the range.
By their numbers in this assay, from the lowest: compounds 2, 3, 4 and 1 (each within the scatter of the next, the first and the last beyond it).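

On the oxygen on an unsaturated carbon, putting ethoxycarbonyl in place of allyl gives a 1.0-fold higher number from compound 3 to compound 4 (0.02 log units; within the scatter) in this assay, so exchanging allyl for this larger group, which carries hydrogen-bond acceptors that allyl lacks, leaves the reading within the scatter. Among these compounds, the only earlier step at this oxygen, a 2.3-fold lower number from compound 1 to compound 2 (0.36 log units; beyond the scatter), lay beyond the scatter, so the position is not silent to every change, and the new result adds that a group attached through a carbonyl can read the same as allyl on the core of compound 3. Nothing available explains why this exchange leaves the number in place.

Going by these compounds, an amine or a carboxylic acid at the end of the group on this oxygen would test the position with a very different kind of substituent, and how either would read remains open. Also open, on these data alone, is whether ethoxycarbonyl would read the same on the shorter side chain of compound 2 as it does on the longer one of compound 4, as this single step comes from one chain length only.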